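Ester to amide at the carbonyl of the phenyl series

The source may hold more compounds than are shown below. What is called first, only, known or untested is meant among the compounds shown, and "the series" means these compounds.

Compound 1 `COC(=O)c1c(O)c2ccccc2n(C)c1=O` gives 58.8% in a functional assay on the whole organism (strain Fischer 344) for inhibition, with Rattus norvegicus as the target, read by paw edema, at a dose of 0.01 mmol/kg by the intraperitoneal route; a higher number here means more inhibition at the dose given (going by the name of the read-out), a lower number less inhibition. Compound 2 `COC(=O)c1c(O)c2ccccc2n(-c2ccccc2)c1=O` gives 37.1% in the same test. Among the measured compounds shown here, the one step recorded between them, phenyl in place of methyl on an aromatic nitrogen, comes out as a number 21.7 percentage points lower from compound 1 to compound 2 (beyond the scatter). For the measured compounds named here, on the two numbers at hand compound 2 stands lowest, and its only neighbour is compound 1, which sits higher by more than the scatter.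

Compound 3 `Nc1ccccc1NC(=O)c1c(O)c2ccccc2n(-c2ccccc2)c1=O` is not yet measured. It differs from compound 2 by (2-aminophenyl)amino in place of methoxy on a carbonyl carbon, so the change sits on the carbonyl carbon and leaves the aromatic nitrogen untouched. Going by the values given here, no measured step touches that carbonyl carbon; the single step in hand concerns the nitrogen substituent and gives no guide to what an amide in place of the ester does. With nothing to lean on, no step beyond the scatter is expected in either direction.

Compound 3 is therefore estimated at 40%, with a range of 15% to 65%. This estimate corresponds to an expected change of a number 2.9 percentage points higher from compound 2 to compound 3 (within the scatter), within the scatter.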

Compound 3, a percentage reported as inhibition, in the whole organism at one dose (the size of the read-out at that dose, not a potency): 48.5%
Compound 3: the middle estimate sits 8.5 percentage points below what was measured; low and high end bracket the measured number.
By their numbers in this assay, from the lowest: compound 2; then compound 3; then compound 1.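

At the carbonyl carbon, the exchange of methoxy for (2-aminophenyl)amino gives, in this assay, a number 11.4 percentage points higher from compound 2 to compound 3 (beyond the scatter), so this carbonyl substituent does affect the read-out at the dose given, whereas the earlier step concerned only the group on the aromatic nitrogen. The position also accepts a much larger group without loss of inhibition in this pair, with the entering group bringing one six-membered aromatic ring of carbon only and hydrogen-bond donors that methoxy does not have. These features change together, so the step cannot be assigned to any one of them, and the data on hand offer no explanation for it.

Going by these compounds, the contribution of the ring amino group remains open: phenylamino, plain amino or a carboxylic acid on the same carbonyl carbon would help separate the effects of the amide link, the ring and its amino group. Among the compounds shown here, it is also open whether (2-aminophenyl)amino would shift the read-out in the same direction with methyl rather than phenyl on the aromatic nitrogen, as the single pair here comes from the phenyl series alone.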